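This account rests on a few compounds, and the source may have more. Where it says the series, first, only, none or still open, it means among the compounds named here.

In an ADME assay on MDBK cells (Bos taurus) for cytotoxicity, read by MTT assay, with a stated time of 96 h (a higher number here means that more compound is tolerated, a lower number that less compound is tolerated), compound 1 (`COc1ccc(-c2nc3cc(C(F)(F)F)ccc3[nH]2)c([N+](=O)[O-])c1`) gives 55000 nM and compound 2 (`COc1ccc(-c2nc3cc(Cl)c(Cl)cc3[nH]2)c([N+](=O)[O-])c1`) gives 28000 nM as its reading. Compound 3 (`O=[N+]([O-])c1ccc(-c2nc3cc(Cl)c(Cl)cc3[nH]2)cc1`) gives 56000 nM in the same test, level with both within the usual scatter. No two of these compounds differ in one place only, so no single change has yet been measured. The step from compound 3 to compound 4 (`CC(=O)Nc1ccc(-c2nc3cc(Cl)c(Cl)cc3[nH]2)cc1`) puts acetamido in place of nitro on an aromatic carbon, para to a large group (acetamido in place of nitro on an aromatic carbon). Within the data shown here, with no measured step to lean on, no change beyond the scatter is expected in this assay in either direction. The expected move is a 1.2-fold lower number from compound 3 to compound 4 (0.09 log units; within the scatter) and stays inside the scatter. For compound 4 the estimated value is 45000 nM with a range from 18000 nM to 100000 nM in repeat measurements.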

Compound 4, half-maximal cytotoxic concentration: 58000 nM
Compound 4: middle estimate off by 1.3-fold (0.11 log units), on the low side, and the stated range covers the measured number.
By their numbers in this assay, from the lowest: compounds 2, 1, 3 and 4 (each within the scatter of the next, the first and the last beyond it).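

In this assay, among these compounds, this is the first change measured at a single place, and it gives a 1.0-fold higher number from compound 3 to compound 4 (0.02 log units; within the scatter) on an aromatic carbon para to a large group. Acetamido and nitro therefore cannot be told apart here, even though acetamido carries a hydrogen-bond donor and nitro carries none. Nothing measured here bears on this result.

On these data alone, whether an amine or a carboxylic acid on this carbon would also read level with these two remains open. So does whether the same swap would give the same result on another core, such as that of compound 1.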